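The compounds below may be only part of what the source reports. "The series", "measured", "known", "first", "only" and "open" are said of these compounds alone.

Notes on the anilino-pyrimidine series. Compound 1 `CCc1ccc(Nc2nccc(-c3cnccn3)n2)cc1` gives 1900 nM in a functional assay for inhibition, with Homo sapiens as the target (a higher number here means a weaker inhibitor, a lower number a stronger inhibitor), compound 3 `CCc1cccc(Nc2nccc(-c3ccccn3)n2)c1` gives 1400 nM, and compound 2 `CCOC(=O)c1ccc(Nc2nccc(-c3cccnc3)n2)cc1` gives 12400 nM. Compound 2 therefore stands highest of the three numbers and is the weakest inhibitor here, since its gaps to compound 1 and to compound 3 both lie beyond the scatter. Compound 4 `CNc1ccc(Nc2nccc(-c3cccnc3)n2)cc1` has not yet been measured; it differs from compound 2 by methylamino in place of ethoxycarbonyl on an aromatic carbon. Going by the values given here, no measured pair shows this change, so the size of the step is open. Given that compound 2 sits at 12400 nM while the other two members lie well lower, a move toward a lower number is expected for compound 4, as a 4.1-fold lower number from compound 2 to compound 4 (0.62 log units; beyond the scatter), with the value estimated at 3000 nM in a range of 800 nM to 12000 nM.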

Compound 4, half-maximal inhibitory concentration: 2100 nM
The estimate for compound 4 lay 1.4-fold (0.15 log units) above the measured number; the measured number falls inside the stated range.
By their numbers in this assay, from the lowest: compounds 3, 1 and 4 (each within the scatter of the next); then compound 2.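

Going by these compounds alone, the first one-place comparison shows that the aromatic carbon para to a large group responds to its substituent: methylamino in place of ethoxycarbonyl gives a 5.9-fold lower number from compound 2 to compound 4 (0.77 log units; beyond the scatter) in this assay. This single pair changes heavy-atom count and hydrogen-bond donor count together, so it cannot separate the two. Nothing available explains the step.

The compounds shown leave open how a primary amine, a carboxylic acid or a longer alkylamino chain would read at this carbon. As far as these compounds go, whether the step carries over to a different core also remains open.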